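The source may report more compounds than this note shows. Statements on the series, on what has been measured and on what is new or still open speak of the compounds shown alone.

Measured so far:
compound 1 `Cc1ccc(-n2cnc3cnc(-c4ccc(F)cc4C)cc32)cc1` — 140 nM
compound 2 `COc1cc(F)ccc1-c1cc2c(cn1)ncn2-c1ccc(OC(F)F)cc1` — 93 nM
compound 3 `Fc1ccc(-c2cc3c(cn2)ncn3-c2ccc(OC(F)F)cc2)c(C(F)(F)F)c1` — 1500 nM

In a functional assay on HL-60 cells (Homo sapiens) for activation, read by flow cytometry, with a stated time of 4 days (a lower number here means that less compound is needed, a higher number that more compound is needed for the effect), compound 2 gives the lowest of the three numbers; compound 1 lies close to it, within the scatter, while compound 3 lies far above. Among the compounds with values here, the only single-point step among the measured compounds is a 16-fold higher number from compound 2 to compound 3 (1.21 log units; beyond the scatter), which shows that the group on this aromatic carbon can move the read-out strongly.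

Compound 4 `CCc1ccccc1-c1cc2c(cn1)ncn2-c1ccc(OC(F)F)cc1` differs from compound 2 in one place: 2-ethylphenyl in place of 4-fluoro-2-methoxyphenyl on an aromatic carbon. Within the data shown here, no measured step covers exactly this change. The step from compound 2 to compound 3 bears on it only loosely: it records a large loss when methoxy is exchanged, but for trifluoromethyl, not ethyl. Compound 1, carrying methyl in place of methoxy together with a different aryl elsewhere, gives 140 nM and stays within the scatter of compound 2, which suggests that a small alkyl here is tolerated. With ethyl rather than methyl and the fluorine also removed, a modest rise in this assay is expected, well short of compound 3. Compound 4 is expected to give 250 nM, between 80 nM and 800 nM. This corresponds to an expected step of a 2.7-fold higher number from compound 2 to compound 4 (0.43 log units; beyond the scatter).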

Compound 4, half-maximal effective concentration: 2900 nM
Estimate against measurement, compound 4: 12-fold (1.06 log units) below; measured number outside the range, above it.
By their numbers in this assay, from the lowest: compounds 2 and 1 (each within the scatter of the next); then compounds 3 and 4 (each within the scatter of the next).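

In this assay, the change to 2-ethylphenyl gives a 31-fold higher number from compound 2 to compound 4 (1.49 log units; beyond the scatter), a large step of the same kind as a 16-fold higher number from compound 2 to compound 3 (1.21 log units; beyond the scatter), and compound 3 and compound 4 lie within the scatter of each other. A large rise at this aromatic carbon, next to the ring nitrogen, is therefore not tied to trifluoromethyl alone: two different replacements of the 4-fluoro-2-methoxyphenyl group, one with and one without the fluorine, both end far above compound 2, so the methoxy-bearing aryl is the only one of these three on this shared core that keeps the number low. Nothing available explains this rise.

The step to compound 4 exchanges methoxy for ethyl and drops the fluorine at once, so the compounds shown leave open how much of it belongs to each change; a plain 2-methoxyphenyl, or ethyl with the fluorine kept, would separate the two. Also open, as far as these compounds go, is whether other groups in the place of methoxy, such as an amine, a hydroxyl or a longer ether chain, keep the number near that of compound 2.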